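A few compounds are considered here, and "the series" means these few. Any claim that something is new, unique, unknown or untested is made for them only; others in the source may bear on it.

Measured so far in an assay on isolated protein (urine) for inhibition of Myeloperoxidase (Homo sapiens), with a stated time of 5 min; a lower number here means a stronger inhibitor, a higher number a weaker inhibitor:
- compound 1, `CCCc1c[nH]c2ccc(F)cc12`: > 100 nM
- compound 2, `ONCCCc1c[nH]c2ccc(F)cc12`: 11 nM
- compound 3, `CNC(=O)CCCc1c[nH]c2ccc(F)cc12`: 40 nM

The value of compound 1 is a limit of this assay, not a number (the limit of > 100 nM in this assay, at which 1 of the 3 values shown sits). Compound 3 holds the higher of the two numbers obtained; its nearest neighbour is compound 2, and the step of a 3.6-fold higher number from compound 2 to compound 3 (0.56 log units; beyond the scatter) is beyond the scatter. Against compound 1, both substitutions on the chain carbon moved the number down: an at least 9.0-fold lower number from compound 1 to compound 2 (0.95 log units; beyond the scatter) and an at least 2.5-fold lower number from compound 1 to compound 3 (0.39 log units; beyond the scatter).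

Compound 4, `CCNC(=O)CCCc1c[nH]c2ccc(F)cc12`, differs from compound 3 by methyl in place of hydrogen on a saturated chain carbon bound to an amide-type nitrogen. For the measured compounds named here, none of the measured steps touches this position: all three concern the group on the chain carbon three bonds from the aromatic carbon, while the substituent on the amide-type nitrogen is unchanged across compounds 2 and 3. Going by the values given here, there is therefore no measured step that bears directly on the change from compound 3 to compound 4, and no step beyond the scatter is expected in this assay, in either direction.

Compound 4 is thus estimated at 40 nM in this assay, with a range of 15 nM to 110 nM. The expected step is no change at the digits printed from compound 3 to compound 4 (within the scatter), within the scatter.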

Compound 4, half-maximal inhibitory concentration: 182 nM
Compound 4: middle estimate off by 4.6-fold (0.66 log units), on the low side; measured number outside the range, above it.
By their numbers in this assay, from the lowest: compound 2; then compound 3; then compound 4.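

In this assay the far end of the amide substituent turns out to matter: going from methylcarbamoyl to ethylcarbamoyl adds one methyl on the saturated chain carbon bound to an amide-type nitrogen, and the number rises beyond the scatter (a 4.6-fold higher number from compound 3 to compound 4 (0.66 log units; beyond the scatter)). The earlier compounds shown here varied only the group on the chain carbon three bonds from the aromatic carbon, whereas this result shows that the amide-type nitrogen substituent is itself a sensitive position, and it widens the distance from the hydroxyamino compound (a 17-fold higher number from compound 2 to compound 4 (1.22 log units; beyond the scatter)). Compound 1 sits at a limit of the assay, not a number, so its step to compound 4 cannot be read: (the limit of > 100 nM in this assay, at which 1 of the 4 values shown sits).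

From the compounds shown here alone, two amides give a single step, so it remains open whether the number keeps rising with a longer chain on the amide nitrogen, such as propyl or butyl, or with a cyclopropyl group there. Going by these compounds, the unsubstituted carbamoyl and a carboxylic acid at the same chain end are also open, and these would show whether any amide comes close to the hydroxyamino compound.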